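A Benzyl Substituent Swap in a Prolyl Hydroxylase Series

The compounds below may be only part of what the source reports. "The series", "measured", "known", "first", "only" and "open" are said of these compounds alone.

Among the measured compounds shown here, compound 2 `O=C(O)CNC(=O)c1c(O)c2c(n(Cc3ccc(Cl)cc3)c1=O)CCOC2` holds the lower of the two numbers so far: in an assay on Sf9 cells for inhibition of prolyl hydroxylase EGLN2 (Homo sapiens), read by TR-FRET, with stated times of 30 min and 2 h (a higher number here means a weaker inhibitor, a lower number a stronger inhibitor), compound 2 gives 5.9 nM, whereas compound 1 `O=C(O)CNC(=O)c1c(O)c2c(n(Cc3ccc(C(F)(F)F)cc3)c1=O)CCOC2` gives 14 nM. For the measured compounds named here, the single measured step, a 2.4-fold lower number from compound 1 to compound 2 (0.38 log units; beyond the scatter), came from a chloro in place of a trifluoromethyl on an aromatic carbon. Compound 3 `N#Cc1ccc(Cn2c3c(c(O)c(C(=O)NCC(=O)O)c2=O)COCC3)c(F)c1` differs from compound 2 by 4-cyano-2-fluorophenyl in place of 4-chlorophenyl on a saturated chain carbon bound to an aromatic nitrogen. That measured step touches the same ring but is a different kind of change, so it offers only a loose guide; the step into compound 3 is expected to be small, a 1.7-fold higher number from compound 2 to compound 3 (0.23 log units; within the scatter), and could fall either way. Compound 3 is therefore estimated at 10 nM, within 4 nM to 30 nM.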

Compound 3, half-maximal inhibitory concentration: 6.3 nM
Beside the measured number, compound 3's estimate is 1.6-fold (0.20 log units) above it; the range from low to high includes it.
By their numbers in this assay, from the lowest: compounds 2 and 3 (each within the scatter of the next); then compound 1.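

With 4-cyano-2-fluorophenyl at the saturated chain carbon bound to an aromatic nitrogen, this assay shows a 1.1-fold higher number from compound 2 to compound 3 (0.03 log units; within the scatter), so compound 2 and compound 3 cannot be told apart. The same group, set against 4-(trifluoromethyl)phenyl, gives a 2.2-fold lower number from compound 1 to compound 3 (0.35 log units; beyond the scatter), showing that this position accepts a ring bearing both a nitrile and a fluorine. No data at hand explain these numbers. The compounds shown leave open how the nitrile and the fluorine each perform alone on the ring. They also leave open whether a methoxy group or an amine there would match these numbers.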